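An Open-Chain Amide in Place of the Cyclic Urea

The source may hold more compounds than are shown below. What is called first, only, known or untested is meant among the compounds shown, and "the series" means these compounds.

Three compounds share one core and differ only in the group on a saturated chain carbon bound to an aromatic carbon and a saturated chain carbon. In an assay on CHO cells for displacement of a labelled ligand from prostaglandin E2 receptor EP3 subtype (Homo sapiens), read by radioligand binding (a higher number here means a weaker inhibitor, a lower number a stronger inhibitor), compound 1 `CC(C)C(c1nnc[nH]1)c1ccc(-c2ccc3cccc(F)c3c2)[nH]c1=O` gives 12 nM, compound 2 `CC(C)C(c1ncc[nH]1)c1ccc(-c2ccc3cccc(F)c3c2)[nH]c1=O` gives 7.3 nM, and compound 3 `CC(C)C(c1ccc(-c2ccc3cccc(F)c3c2)[nH]c1=O)N1CCNC1=O` gives 9.1 nM. Compound 3 stands second highest of the three, nearest compound 2 and furthest from compound 1, both within the scatter. Compound 4 `CC(C)NC(=O)CC(c1ccc(-c2ccc3cccc(F)c3c2)[nH]c1=O)C(C)C` carries (isopropylcarbamoyl)methyl in place of 2-oxoimidazolidin-1-yl on a saturated chain carbon bound to an aromatic carbon and a saturated chain carbon. The steps seen so far at this position, a 1.6-fold lower number from compound 1 to compound 2 (0.22 log units; within the scatter), a 1.3-fold lower number from compound 1 to compound 3 (0.12 log units; within the scatter) and a 1.2-fold higher number from compound 2 to compound 3 (0.10 log units; within the scatter), all lay within the scatter. Compound 4 is therefore expected to show no step beyond the scatter, a 1.1-fold higher number from compound 3 to compound 4 (0.04 log units; within the scatter). The estimated value of compound 4 in this assay is 10 nM, between 4 nM and 30 nM.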

Compound 4, inhibition constant: 5.8 nM
Compound 4: middle estimate off by 1.7-fold (0.24 log units), on the high side, and the stated range covers the measured number.
By their numbers in this assay, from the lowest: compounds 4, 2, 3 and 1 (each within the scatter of the next, the first and the last beyond it).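

The open-chain (isopropylcarbamoyl)methyl group, which has no ring, stays level with both ring-bearing neighbours in this assay, with a 1.6-fold lower number from compound 3 to compound 4 (0.20 log units; within the scatter) and a 1.3-fold lower number from compound 2 to compound 4 (0.10 log units; within the scatter), so a ring is not required at this position among these compounds. Against the 4H-1,2,4-triazol-3-yl group, however, comes the first step here to pass the scatter, a 2.1-fold lower number from compound 1 to compound 4 (0.32 log units; beyond the scatter), though a modest one. No measurement offered here accounts for this step. From the compounds shown here alone, whether a carboxylic acid, a primary amine or a longer chain on this carbon would hold the same level remains open.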